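The source may report more compounds than this note shows. Statements on the series, on what has been measured and on what is new or still open speak of the compounds shown alone.

Measured so far
compound 1 `CC(C)n1c(=O)n(C(=O)NCCN2CCN(C)CC2)c2ccccc21` — in a functional assay for antagonist activity at 5-hydroxytryptamine receptor 4 (Cavia porcellus) (on this read-out lower numbers stand for lower potency and higher numbers for higher potency (the scale is a negative logarithm)), compound 1 gives < 6, a limit of the assay
compound 2 `CC(C)n1c(=O)n(C(=O)NCCN2CCN(C)CC2)c2cc(F)c(N)cc21` — in this assay compound 2 gives < 6, likewise a limit

Where compound 2 stands: its value in this assay is a limit and not a number, so the read-out gives no figure to rank it by. Compound 1 also sits at that limit, and the two share the shared core. Within the data shown here, both values sit on the same line, (the limit of < 6 in this assay, at which 2 of the 2 values shown sit), so no step between measured compounds can be computed here.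

Compound 3 `CC(C)n1c(=O)n(C(=O)NCCN2CCN(C)CC2)c2cc(F)ccc21` is the next member, not yet measured. It differs from compound 2 by hydrogen in place of amino on an aromatic carbon, in words hydrogen in place of amino on an aromatic carbon, ortho to a fluoro group, meta and para to a fused ring.

Among the measured compounds shown here, no measured step is available, so the expectation for the step from compound 2 to compound 3 rests on the limit alone. The step that the limit leaves unreadable from compound 2 to compound 3 in this assay is expected to be none beyond the scatter, in either direction. Compound 3 is thus estimated at 5.5, within 4.5 to 6.3, with a high chance that the assay again reports only a limit.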

Compound 3, negative logarithm of the antagonist equilibrium constant: 6.88
The estimate for compound 3 lay 1.38 log units below the measured number, outside the stated range (above it).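

Working from the two steps in this assay, the first number in the series appears once the amino group is gone: hydrogen in place of amino on an aromatic carbon gives a number at least 0.88 log units higher from compound 2 to compound 3 (beyond the scatter). Fluoro in place of hydrogen on an aromatic carbon gives a number at least 0.88 log units higher from compound 1 to compound 3 (beyond the scatter), so this aromatic carbon can also carry a change that moves the read-out off the limit. Compound 2 carries the same fluoro group yet stays at its limit, so the fluoro group alone does not guarantee a number, and both steps are only minimum sizes, as each starts from a limit: the limit of < 6 in this assay, at which 2 of the 3 values shown sit.

On these data alone, the true size of either step remains open, since neither compound 1 nor compound 2 gives a figure to subtract from. As far as these compounds go, it is also open whether a chloro or methoxy group in place of the fluoro group would hold the gain, and whether a hydroxyl or methyl group in place of the amino group would return the read-out to the limit.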